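Mirror-image centre on a weakly active stilbene acid

This account rests on a few compounds, and the source may have more. Where it says the series, first, only, none or still open, it means among the compounds named here.

Measured in a functional assay on B16-F10 cells (Mus musculus) for antiproliferative activity, read by CCK-8 assay, with a stated time of 48 h; a higher number here means a weaker inhibitor, a lower number a stronger inhibitor:
- compound 1 `COc1ccc(/C=C\c2cc(OC)c(OC)c(OC)c2)cc1OCc1ccc(CNC(C)(C)C(=O)O)cc1`: > 10000 nM (a limit)
- compound 2 `COc1ccc(/C=C\c2cc(OC)c(OC)c(OC)c2)cc1OCc1ccc(C=O)cc1`: 4200 nM
- compound 3 `COc1ccc(/C=C\c2cc(OC)c(OC)c(OC)c2)cc1OCc1ccc(CN2CCCC[C@H]2C(=O)O)cc1`: > 10000 nM (a limit)

Only compound 2 gives a true number here. Compound 3 has no number and stands at the limit of > 10000 nM in this assay, at which 2 of the 3 values shown sit.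

The next compound, compound 4 `COc1ccc(/C=C\c2cc(OC)c(OC)c(OC)c2)cc1OCc1ccc(CN2CCCC[C@@H]2C(=O)O)cc1`, has the same atoms and bonds as compound 3: the two compounds have the same atoms and bonds and differ only in configuration as drawn: 1 of 2 stereo elements differ; a stereocentre at a saturated ring carbon is drawn S in compound 3 and R in compound 4. A stereocentre is a carbon whose groups can be arranged in two mirror-image ways, so only the spatial arrangement changes.

Three measured steps lie nearby. Exchanging the side chain for formyl gives an at least 2.3-fold lower number from compound 1 to compound 2 (0.37 log units; beyond the scatter). Exchanging formyl for (2-carboxypiperidin-1-yl)methyl gives an at least 2.3-fold higher number from compound 2 to compound 3 (0.37 log units; beyond the scatter). The third is a step that the two limits leave unreadable from compound 1 to compound 3. All three replace one group with another, and none changes configuration alone, so they bear on compound 4 only indirectly.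

The starting point is compound 3, whose > 10000 nM is a limit. No step beyond the scatter is expected in this assay, and no direction can be favoured. The expected change is a step that the limit leaves unreadable from compound 3 to compound 4. For compound 4 the estimated value is 12000 nM, with an expected range from 5000 nM to 30000 nM.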

Compound 4, half-maximal inhibitory concentration: > 10000 nM
Compound 4 was reported as a limit; the forecaster's own chance of this, stated with the estimate: 80%; the middle value is on the limit's open side.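

Compound 4 gives > 10000 nM in this assay, which is a limit, so neither drawing of the stereocentre at the saturated ring carbon has yet yielded a true number: the limit of > 10000 nM in this assay, at which 3 of the 4 values shown sit. Exchanging formyl for (2-carboxypiperidin-1-yl)methyl gives an at least 2.3-fold higher number from compound 2 to compound 4 (0.37 log units; beyond the scatter), so this weakening appears with the R drawing as well as with the S drawing and does not depend on one configuration alone. The steps from compound 3 to compound 4 and from compound 1 to compound 4 cannot be read, with a limit at both ends, so whatever the change of configuration does stays hidden: the fact that compounds 3 and 4 differ only in the configuration as drawn.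

As far as these compounds go, whether the two mirror-image forms differ at all remains open, as a true number for each would be needed to tell. Also open, from the compounds shown here alone, is whether a methyl ester in place of the carboxylic acid, or a plain piperidin-1-ylmethyl group without the carboxy group, would bring the number back towards that of the formyl compound.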